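This account rests on a few compounds, and the source may have more. Where it says the series, first, only, none or still open, it means among the compounds named here.

Working notes on the series. The compounds are scored in a functional assay on Ehrlich cells (Mus musculus) for cytotoxicity, read by trypan blue exclusion, with a stated time of 2 h, tested at 25 ug/mL; a lower number here means a stronger effect, a higher number a weaker effect of the compound at the concentration tested. Going by the values given here, compound 1 `Cc1c(C(=O)N=[N+]=[N-])[n+]([O-])c2cc(Cl)ccc2[n+]1[O-]` gives 98% there, the highest of the three numbers measured so far. Among the compounds with values here, compound 2 `COc1ccc2c(c1)[n+]([O-])c(C(=O)N=[N+]=[N-])c(C)[n+]2[O-]` gives 80.7%, and the single one-place step recorded, a number 17.3 percentage points lower from compound 1 to compound 2 (beyond the scatter), is a methoxy in place of chloro on an aromatic carbon. Within the data shown here, compound 3 `COc1ccc(NC(=O)Nc2c(C)[n+]([O-])c3ccc(Cl)cc3[n+]2[O-])cc1` gives 79.2%; no step to it is recorded, but it is a compound in which the group of 5 heavy atoms (1 carbon, 3 nitrogen, 1 oxygen) carried by compound 1 is absent, and its number stands beyond the scatter below that of compound 1.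

Compound 4 `Cc1c(NC(=O)OC(C)C)[n+]([O-])c2cc(Cl)ccc2[n+]1[O-]` is not yet measured. It differs from compound 1 as follows: a group of 7 heavy atoms (4 carbon, 1 nitrogen, 2 oxygen; no ring) in place of a group of 5 heavy atoms (1 carbon, 3 nitrogen, 1 oxygen; no ring), on an aromatic carbon. The step from compound 1 to compound 2 concerns a different place on the core and does not bear directly on this change. Among the measured compounds shown here, the only pointer is that compound 3, lacking the same group of 5 heavy atoms, gives 79.2% against 98% for compound 1. The expectation is therefore a step downward beyond the scatter, a number 18 percentage points lower from compound 1 to compound 4 (beyond the scatter). Compound 4 is estimated at 80%, within 62% to 96%.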

Compound 4, a percentage reported as activity, at one concentration (the size of the read-out at that concentration, not a potency): 97%
Estimate against measurement, compound 4: 17 percentage points below, outside the stated range (above it).
By their numbers in this assay, from the lowest: compounds 3 and 2 (each within the scatter of the next); then compounds 4 and 1 (each within the scatter of the next).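

In this assay the step of a number 1 percentage points lower from compound 1 to compound 4 (within the scatter) shows that, on this aromatic carbon next to the ring nitrogen, (isopropoxycarbonyl)amino can stand in place of the group of 5 heavy atoms with no difference that this read-out can resolve. The loss of that group therefore does not by itself bring a number beyond the scatter from that of compound 1, even though the entering group is larger and adds a hydrogen-bond donor. No measurement at hand accounts for this result.

The compounds shown leave open what an amine or a carboxylic acid at this place, or a longer chain in place of the isopropyl, would give. They also leave open whether methoxy in place of chloro would bring a step like a number 17.3 percentage points lower from compound 1 to compound 2 (beyond the scatter) when (isopropoxycarbonyl)amino is present.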